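A few compounds are considered here, and "the series" means these few. Any claim that something is new, unique, unknown or untested is made for them only; others in the source may bear on it.

Compound 2 `Nc1nc(NCc2cccnc2)nc2sc(-c3ccco3)nc12` is the starting point. In a functional assay on CHO cells for agonist activity at adenosine receptor A2b (Homo sapiens), read by scintillation counting and cAMP accumulation, with a stated time of 150 min, in the presence of a further agent that is not named here (a lower number here means a stronger inhibitor, a higher number a weaker inhibitor), compound 2 gives 109 nM, the lowest of the three numbers measured. Compound 1 `Nc1nc(NCc2cccs2)nc2sc(-c3cccs3)nc12` gives 547 nM in this assay, and compound 3 `COc1ccccc1CNc1nc(N)c2nc(-c3cccs3)sc2n1` gives 4570 nM. Compounds 1 and 3 differ in one place, and the step from one to the other is an 8.4-fold higher number from compound 1 to compound 3 (0.92 log units; beyond the scatter), which shows that exchanging the group on the saturated chain carbon bound to a nitrogen on the aromatic ring can move the number well beyond the scatter. Compound 4 `Nc1nc(NCc2ccco2)nc2sc(-c3ccco3)nc12` is not yet measured. It differs from compound 2 as follows: furan-2-yl in place of pyridin-3-yl on a saturated chain carbon bound to a nitrogen on an aromatic ring. This is the same place that was altered between compound 1 and compound 3, so that step is the one that bears on the expectation. Compounds 1 and 2 differ in two places, so their values alone cannot be split into a single effect. Going by the values given here, with one relevant step of modest size and no direct precedent for this exact swap, the expected step from compound 2 to compound 4 is a 2.3-fold higher number from compound 2 to compound 4 (0.36 log units; beyond the scatter), a modest rise in the number. Compound 4 is therefore estimated at 250 nM, with a range from 80 nM to 800 nM.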

Compound 4, half-maximal inhibitory concentration: 82 nM
Beside the measured number, compound 4's estimate is 3.0-fold (0.48 log units) above it; low and high end bracket the measured number.
By their numbers in this assay, from the lowest: compounds 4 and 2 (each within the scatter of the next); then compound 1; then compound 3.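

In this assay, putting furan-2-yl in place of pyridin-3-yl on a saturated chain carbon bound to a nitrogen on an aromatic ring gives a 1.3-fold lower number from compound 2 to compound 4 (0.12 log units; within the scatter), so this number does not separate these two rings at this place, even though one is a five-membered ring with an oxygen and the other a six-membered ring with a nitrogen. Going by these compounds alone, the only earlier step at this place, an 8.4-fold higher number from compound 1 to compound 3 (0.92 log units; beyond the scatter), went beyond the scatter, so the two steps together show that the outcome of an exchange here depends on which groups are exchanged, although that earlier pair also carries a different group on the core. No measurement is available that would explain why these two rings give matching numbers. As far as these compounds go, what stays open is whether this match extends to a plain phenyl ring, a piperidine ring or a longer chain in the same place. Also open, from the compounds shown here alone, is whether 2-methoxyphenyl would give a step of similar size on the core of compound 2 and compound 4 as it does on the core of compound 1 and compound 3.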